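Thiazole attachment in the cyclopropane amide series

The source may hold more compounds than are shown below. What is called first, only, known or untested is meant among the compounds shown, and "the series" means these compounds.

Compound 3 `CC[C@H](C)[C@H](N)CN(C(=O)[C@@H]1C[C@H]1c1nccs1)c1ccc(-c2ccccc2)cc1` gives 210 nM in a functional assay for agonist activity at G protein-coupled receptor 88 (Homo sapiens), read by HTRF and cAMP accumulation (on this read-out higher numbers stand for an effect only at larger amounts of compound and lower numbers for an effect already at smaller amounts), the lowest number of the three measured. Compound 1 `CC[C@H](C)[C@H](N)CN(C(=O)[C@@H]1C[C@H]1c1cc(F)ccc1F)c1ccc(-c2ccccc2)cc1` gives 770 nM in this assay, and compound 2 `CC[C@H](C)[C@H](N)CN(C(=O)[C@@H]1C[C@H]1c1cc(F)cc(F)c1)c1ccc(-c2ccccc2)cc1` gives 960 nM. The two steps onto the thiazole, a 3.7-fold lower number from compound 1 to compound 3 (0.56 log units; beyond the scatter) and a 4.6-fold lower number from compound 2 to compound 3 (0.66 log units; beyond the scatter), are both beyond the scatter and modest in size, while the exchange of difluorophenyl patterns, a 1.2-fold higher number from compound 1 to compound 2 (0.10 log units; within the scatter), stays within the scatter.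

Compound 4 `CC[C@H](C)[C@H](N)CN(C(=O)[C@@H]1C[C@H]1c1csc(C)n1)c1ccc(-c2ccccc2)cc1` carries 2-methyl-1,3-thiazol-4-yl in place of 1,3-thiazol-2-yl on a saturated ring carbon. Within the data shown here, no measured step concerns the point of attachment or a methyl on the thiazole; the only steps at this position trade a difluorophenyl for the thiazol-2-yl. The measured data therefore give no direction for this change, and a step on either side of the scatter is possible. The expectation for compound 4 is a value near 400 nM, between 120 nM and 1500 nM, which would be a step of a 1.9-fold higher number from compound 3 to compound 4 (0.28 log units; within the scatter) and is estimated with low confidence.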

Compound 4, half-maximal effective concentration: 1500 nM
Estimate against measurement, compound 4: 3.8-fold (0.57 log units) below, within the range that was stated.
By their numbers in this assay, from the lowest: compound 3; then compounds 1, 2 and 4 (each within the scatter of the next).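

Exchanging 1,3-thiazol-2-yl for 2-methyl-1,3-thiazol-4-yl on the cyclopropane removes the gain seen with compound 3 in this assay (a 7.1-fold higher number from compound 3 to compound 4 (0.85 log units; beyond the scatter)), so the presence of a thiazole alone does not secure a lower number at this position. Compound 4 cannot be told apart from the difluorophenyl compounds (a 1.6-fold higher number from compound 2 to compound 4 (0.19 log units; within the scatter); a 1.9-fold higher number from compound 1 to compound 4 (0.29 log units; within the scatter)), which leaves compound 3 as the only one of the four set apart from the others. No measurement shown here accounts for this difference.

This change combines a new point of attachment with an added methyl, and the compounds shown do not separate the two. As far as these compounds go, the unsubstituted 1,3-thiazol-4-yl and 5-methyl-1,3-thiazol-2-yl would address that, while an amine or carboxylic acid on the thiazole remains open.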